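The source may hold more compounds than are shown below. What is called first, only, known or untested is meant among the compounds shown, and "the series" means these compounds.

Compound 3 `Cc1cccc(C(=O)Nc2cccc(C)n2)c1` holds the lowest of the three numbers recorded in an assay on membranes from brain for binding affinity to metabotropic glutamate receptor 5 (Rattus norvegicus) (a lower number here means a stronger inhibitor, a higher number a weaker inhibitor), where compound 3 gives 1840 nM. Compound 1 `Cc1cccc(NC(=O)c2ccccc2)n1` gives 35000 nM in this assay, and compound 2 `Cc1cccc(NC(=O)c2cccc3ccccc23)n1` gives 62800 nM. Going by the values given here, the only step between two compounds that differ in one place is a 19-fold lower number from compound 1 to compound 3 (1.28 log units; beyond the scatter), a methyl in place of hydrogen on an aromatic carbon. Compound 4 `Cc1cccc(NC(=O)c2cccc(C(F)(F)F)c2)n1` differs from compound 3 by trifluoromethyl in place of methyl on an aromatic carbon. Among the compounds with values here, no measured step puts a trifluoromethyl in, so the bearing is indirect: the measured step shows only that a group at this aromatic carbon changes the number strongly. A modest step in either direction, possibly within the scatter, is expected. Compound 4 is therefore estimated at 800 nM in this assay, with a range from 200 nM to 4000 nM. That estimate corresponds to an expected 2.3-fold lower number from compound 3 to compound 4 (0.36 log units; beyond the scatter).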

Compound 4, half-maximal inhibitory concentration: 18700 nM
Beside the measured number, compound 4's estimate is 23-fold (1.37 log units) below it; measured number outside the range, above it.
By their numbers in this assay, from the lowest: compound 3; then compounds 4, 1 and 2 (each within the scatter of the next, the first and the last beyond it).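

In this assay this aromatic carbon proves selective, not merely sensitive to any added group: trifluoromethyl in place of methyl gives a 10-fold higher number from compound 3 to compound 4 (1.01 log units; beyond the scatter) and gives back most of what methyl gained. Set against the unsubstituted compound, trifluoromethyl in place of hydrogen gives only a 1.9-fold lower number from compound 1 to compound 4 (0.27 log units; within the scatter) and so brings no gain beyond the scatter. Nothing measured here accounts for this difference between methyl and trifluoromethyl. On these data alone, whether a chlorine atom, a methoxy group or a longer chain such as ethyl at this carbon would match methyl remains open.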